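The source may report more compounds than this note shows. Statements on the series, on what has been measured and on what is new or still open speak of the compounds shown alone.

Measured so far in a functional assay on HepG2 cells (Homo sapiens) for antiproliferative activity, read by MTT assay, with a stated time of 24 h; a higher number here means a weaker inhibitor, a lower number a stronger inhibitor:
compound 1 `COC(=O)c1scc(-c2ccc(NC(=O)c3ccc4ccccc4c3)cc2)c1OC`: 19500 nM
compound 2 `COC(=O)c1scc(-c2ccc(NC(=O)c3cccc(C(F)(F)F)c3)cc2)c1OC`: 32500 nM
compound 3 `COC(=O)c1scc(-c2ccc(NC(=O)c3cccc(I)c3)cc2)c1OC`: 16500 nM

Compound 3, at 16500 nM, is not separated from the other two compounds. The data show a 1.2-fold lower number from compound 1 to compound 3 (0.07 log units; within the scatter) and a 2.0-fold lower number from compound 2 to compound 3 (0.29 log units; within the scatter).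

Compound 4 `COC(=O)c1scc(-c2ccc(NC(=O)c3cccc(OC(F)(F)F)c3)cc2)c1OC` keeps the shared core and exchanges a single group: trifluoromethoxy in place of iodo on an aromatic carbon. This places trifluoromethoxy in place of iodo on an aromatic carbon, meta to a large group.

No trifluoromethoxy group has been measured in this series. The nearest measured group is the trifluoromethyl of compound 2, which gives 32500 nM. The most relevant evidence is therefore the exchange of trifluoromethyl for iodo, a 2.0-fold lower number from compound 2 to compound 3 (0.29 log units; within the scatter). The two changes from the naphthalen-2-yl of compound 1 point the same way, with a 1.7-fold higher number from compound 1 to compound 2 (0.22 log units; within the scatter) alongside a 1.2-fold lower number from compound 1 to compound 3 (0.07 log units; within the scatter). Across these three compounds, no change at this part of the structure has moved the number beyond the scatter, and none of the three goes against that.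

The size expected here is a 1.5-fold higher number from compound 3 to compound 4 (0.16 log units; within the scatter), so no real shift in either direction is expected. For compound 4 the estimated value in this assay is 24000 nM, with an expected range of 12000 nM to 45000 nM.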

Compound 4, half-maximal inhibitory concentration: 720 nM
Estimate against measurement, compound 4: 33-fold (1.52 log units) above; measured number outside the range, below it.
By their numbers in this assay, from the lowest: compound 4; then compounds 3, 1 and 2 (each within the scatter of the next).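

At this position, on a six-membered aromatic ring of carbon only and meta to a large group, the earlier exchanges had all stayed within the scatter, which could have suggested that the group here mattered little; in this assay, however, trifluoromethoxy in place of iodo gives a 23-fold lower number from compound 3 to compound 4 (1.36 log units; beyond the scatter), so the identity of the group can matter a great deal. The exchange with the closest measured group is just as large, with trifluoromethoxy in place of trifluoromethyl giving a 45-fold lower number from compound 2 to compound 4 (1.65 log units; beyond the scatter), so two groups that differ only by the oxygen of trifluoromethoxy are clearly separated in this series. No measurement available here accounts for this step.

On these data alone, it remains open whether the effect is specific to trifluoromethoxy or extends to other oxygen-linked groups, such as methoxy, ethoxy or phenoxy, and whether trifluoromethoxy gives a similar result elsewhere on the same ring. Also unresolved is whether the step persists when the shared core is changed, for example with a carboxylic acid in place of the methyl ester.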